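Swapping Chloro for Fluoro on the Phenyl Ring

This account rests on a few compounds, and the source may have more. Where it says the series, first, only, none or still open, it means among the compounds named here.

In an assay on isolated protein for inhibition of acid ceramidase (Homo sapiens), read by LC-MS, with a stated time of 1 h (on this read-out lower numbers stand for stronger inhibition and higher numbers for weaker inhibition), compound 3 `O=C(NCCCCc1ccccc1)n1cc(-c2ccc(Cl)cc2)oc1=O` gives 83 nM, which stands lowest among the three numbers measured, yet sits within the scatter of compound 1 `O=C(NCCCCc1ccccc1)n1cc(-c2ccccc2)oc1=O`, which gives 90 nM in this assay. Compound 2 `CC(C)CNC(=O)n1cc(-c2ccccc2)oc1=O` gives 1700 nM in this assay. Compound 4 `O=C(NCCCCc1ccccc1)n1cc(-c2ccc(F)cc2)oc1=O` differs from compound 3 by fluoro in place of chloro on an aromatic carbon. Within the data shown here, the one measured step at that same aromatic carbon, a 1.1-fold lower number from compound 1 to compound 3 (0.04 log units; within the scatter), shows that placing a halogen there hardly moved this assay. Replacing one halogen by another at the same place is therefore expected to give a step of about a 1.2-fold higher number from compound 3 to compound 4 (0.08 log units; within the scatter), not beyond the scatter. Compound 4 is expected to give 100 nM in this assay, with a range from 45 nM to 220 nM.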

Compound 4, half-maximal inhibitory concentration: 185 nM
Compound 4: the middle estimate sits 1.9-fold (0.27 log units) below what was measured; the range from low to high includes it.
By their numbers in this assay, from the lowest: compounds 3 and 1 (each within the scatter of the next); then compound 4; then compound 2.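

At this aromatic carbon, the choice of halogen matters in this assay: fluoro in place of chloro gives a 2.2-fold higher number from compound 3 to compound 4 (0.35 log units; beyond the scatter) and so lies beyond the scatter, which the earlier chloro in place of hydrogen step did not. Fluoro in place of hydrogen gives a 2.1-fold higher number from compound 1 to compound 4 (0.31 log units; beyond the scatter) and is also beyond the scatter, so the position is not indifferent to what sits there, although both steps are modest. Nothing available explains the difference between fluoro and chloro here. As far as these compounds go, whether bromo or methoxy at this carbon would give a lower or a higher number remains open.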